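The source may hold more compounds than are shown below. What is called first, only, known or untested is meant among the compounds shown, and "the series" means these compounds.

Compound 1, drawn as `CCCNC(=O)C1CCN(C(=O)c2cc3cc(Br)sc3n2Cc2ccc(OC)cc2)CC1`, gives in an ADME assay on HEK-293T cells (Homo sapiens) for cytotoxicity, read by luminescence and CellTiter-Glo, with a stated time of 24 h (on this read-out higher numbers stand for lower toxicity in this test and lower numbers for higher toxicity in this test), a result of > 100000 nM, which is a limit of the assay rather than a number. Compound 2, drawn as `CCCNC(=O)[C@@H]1C[C@H]2CCC[C@@H](C1)[C@H]2NC(=O)c1cc2sc(Br)cc2n1Cc1ccc(OC)cc1`, gives in this assay a result of > 100000 nM, again a limit of the assay. Both values therefore sit at the limit of > 100000 nM in this assay, at which 2 of the 2 values shown sit. Compound 3, drawn as `CCCNC(=O)[C@@H]1C[C@H]2CCC[C@@H](C1)[C@@H]2NC(=O)c1cc2sc(Br)cc2n1Cc1ccc(OC)cc1`, differs from compound 2 only in configuration: the two compounds have the same atoms and bonds and differ only in configuration as drawn: 1 of 4 stereo elements differ; a stereocentre at a saturated ring carbon is drawn r in compound 2 and s in compound 3. Going by the values given here, no measured step exists for this change, so compound 3 is expected to show no shift beyond the usual scatter, a number no higher from compound 2 to compound 3 (the limit leaves the size open). Compound 3 is estimated at 100000 nM, ranging from 50000 nM to 200000 nM.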

Compound 3, half-maximal cytotoxic concentration: > 100000 nM
Compound 3 was reported as a limit (the forecaster's own chance of this, stated with the estimate: 90%); the middle value lies on the limit itself.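

Going by these compounds alone, the results for compound 2 and compound 3 are both limits of the assay, so no step between them can be read. As far as these compounds go, whether the configuration at that saturated ring carbon changes the true value in this assay remains open.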